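Swapping the aryl on the triazole nitrogen: compound 4

This account rests on a few compounds, and the source may have more. Where it says the series, first, only, none or still open, it means among the compounds named here.

Of the compounds shown here, three sharing one core have been tested in a functional assay on PC-12 cells (Rattus norvegicus) for cytotoxicity, read by MTT assay, with stated times of 2 h and 24 h, tested at 10 uM; on this read-out lower numbers stand for a weaker effect and higher numbers for a stronger effect at the one concentration tested. Compound 1 `CC(C)c1ccc(-n2nc(-c3ccc(C(F)(F)F)cc3O)nc2-c2ccccc2O)cc1` gives 108%. Compound 2 `N#Cc1ccc(-n2nc(-c3ccc(C(F)(F)F)cc3O)nc2-c2ccccc2O)cc1` gives 98.9%, and compound 3 `Cc1ccc(-n2nc(-c3ccc(C(F)(F)F)cc3O)nc2-c2ccccc2O)c(C)c1` gives 106%; the steps of a number 9.1 percentage points lower from compound 1 to compound 2 (within the scatter) and a number 2 percentage points lower from compound 1 to compound 3 (within the scatter) both fall within the usual scatter, so compound 1 cannot be set apart from either.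

Compound 4 `Oc1cc(C(F)(F)F)ccc1-c1nc(-c2ccccc2O)n(-c2ccc(F)cc2F)n1` differs from compound 1 in one place: 2,4-difluorophenyl in place of 4-isopropylphenyl on an aromatic nitrogen. The measured steps that bear on this change are those exchanging the group on the same aromatic nitrogen, a number 2 percentage points lower from compound 1 to compound 3 (within the scatter) and a number 7.1 percentage points higher from compound 2 to compound 3 (within the scatter), both within the scatter. No step beyond the scatter is therefore expected in this assay for compound 4, and the estimated step is a number 4 percentage points lower from compound 1 to compound 4 (within the scatter). Compound 4 is expected to give 104%, between 92% and 114%.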

Compound 4, a percentage reported as activity, at one concentration (the size of the read-out at that concentration, not a potency): 97.9%
Compound 4: the middle estimate sits 6.1 percentage points above what was measured; the measured number falls inside the stated range.
By their numbers in this assay, from the lowest: compounds 4, 2, 3 and 1 (each within the scatter of the next, the first and the last beyond it).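

Within the data shown here, on the aromatic nitrogen, 2,4-difluorophenyl in place of 4-isopropylphenyl gives the one step at this position that passes the usual scatter in this assay: a number 10.1 percentage points lower from compound 1 to compound 4 (beyond the scatter), and it is modest. The steps of a number 8.1 percentage points lower from compound 3 to compound 4 (within the scatter) and a number 1 percentage points lower from compound 2 to compound 4 (within the scatter) stay within the scatter, so compound 4 stands apart from compound 1 only. Nothing measured here explains this step.

On these data alone, whether a phenyl bearing an amine or a carboxylic acid, or a longer chain in place of the aryl group on this nitrogen, would give a larger step remains open.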